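Phenol in place of methoxy on the urea series

The source may report more compounds than this note shows. Statements on the series, on what has been measured and on what is new or still open speak of the compounds shown alone.

In a functional assay on NCI-H322M cells (Homo sapiens) for inhibition, read by sulforhodamine B assay, with a stated time of 48 h (a lower number here means that less compound is tolerated, a higher number that more compound is tolerated), compound 2 `COc1cc(-c2nn(-c3cccc(NC(=O)Nc4ccc(Cl)c(C(F)(F)F)c4)c3)cc2-c2ccncc2)ccc1Cl` gives only the limit > 32500 nM. Compound 1 `O=C(Nc1cccc(-n2cc(-c3ccncc3)c(-c3ccc(Cl)c(O)c3)n2)c1)Nc1cccc(C(F)(F)F)c1` likewise gives only the limit > 32500 nM. Two of two values shown sit at the limit of > 32500 nM in this assay, at which 2 of the 2 values shown sit, so compound 2 stands at the ceiling of what has been measured. Compound 3 `O=C(Nc1cccc(-n2cc(-c3ccncc3)c(-c3ccc(Cl)c(O)c3)n2)c1)Nc1ccc(Cl)c(C(F)(F)F)c1` differs from compound 2 by hydrogen in place of methyl on an oxygen on an aromatic ring. Compound 1 already carries this hydroxy group and reaches only its limit. On that basis the expected step is a step that the limit leaves unreadable from compound 2 to compound 3, none beyond the scatter. Compound 3 is therefore estimated at 40000 nM, within 15000 nM to 100000 nM, most likely reported again as a limit.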

Compound 3, concentration lethal to 50% of the cells: 24700 nM
Compound 3: middle estimate off by 1.6-fold (0.21 log units), on the high side; measured number inside the range.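

Of the three compounds, only compound 3 gives a number rather than a limit in this assay. Methoxy to hydroxy on the 4-chloro-3-methoxyphenyl group gives an at least 1.3-fold lower number from compound 2 to compound 3 (0.11 log units; that floor lies within the scatter), and chloro in place of hydrogen on an aromatic carbon gives an at least 1.3-fold lower number from compound 1 to compound 3 (0.11 log units; that floor lies within the scatter). Both steps are floors, not true sizes, because the other two values are limits: the limit of > 32500 nM in this assay, at which 2 of the 3 values shown sit.

On these data alone, the true size of either step remains open. So does whether an amine in place of the hydroxy, or an ethoxy group on that oxygen, would move the number beyond the scatter.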